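This account rests on a few compounds, and the source may have more. Where it says the series, first, only, none or still open, it means among the compounds named here.

Of the compounds shown here, three have been measured in a functional assay (lung) for inhibition, with Cavia porcellus as the target; on this read-out lower numbers stand for stronger inhibition and higher numbers for weaker inhibition. Compound 1 `CCCC(CCc1nnn[nH]1)Cc1cccc(OCc2ccc3ccccc3n2)c1` gives 16 nM, and that is the lowest of the three numbers. Compound 3 `CC(CCCc1nnn[nH]1)c1ccc(OCc2ccc3ccccc3n2)cc1` gives 170 nM, a higher value than that of compound 1, a gap that lies beyond the usual scatter. Compound 2 `c1ccc2nc(COc3ccc(OCCCc4nnn[nH]4)cc3)ccc2c1` gives 250 nM, the highest of the three, again well beyond the scatter when set against compound 1. For the measured compounds named here, compounds 2 and 3 differ from compound 1 in more than one place, so no single structural step between any two measured compounds can be read from these numbers.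

Compound 4 `CC(CCc1nnn[nH]1)Cc1cccc(OCc2ccc3ccccc3n2)c1` has not yet been measured. It differs from compound 1 in one place only: hydrogen in place of ethyl on a saturated chain carbon, three bonds along the chain from an aromatic carbon. The rest of the structure is kept; only the ethyl branch on the chain is replaced by hydrogen. Going by the values given here, no measured pair shows what such a shortening does in this assay, so the direction of the step is an open question. The expectation is a modest weakening, with the value for compound 4 estimated at 40 nM and a range from 15 nM to 120 nM. That estimate corresponds to a step of a 2.5-fold higher number from compound 1 to compound 4 (0.40 log units; beyond the scatter), which would be only slightly beyond the scatter of repeated measurements.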

Compound 4, half-maximal inhibitory concentration: 150 nM
The estimate for compound 4 lay 3.8-fold (0.57 log units) below the measured number; measured number above the stated range.
By their numbers in this assay, from the lowest: compound 1; then compounds 4, 3 and 2 (each within the scatter of the next).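

In this assay, putting hydrogen in place of ethyl on a saturated chain carbon, three bonds along the chain from an aromatic carbon, gives a 9.4-fold higher number from compound 1 to compound 4 (0.97 log units; beyond the scatter), so inhibition is clearly weaker. For the compounds shown here, this is the first change in the set that can be read in one place alone, and it shows that this part of the chain is not a silent spot: with the rest of the structure kept, losing just two carbons from the branch moves the number well beyond the usual scatter. Seen from one bond further out, the same difference is propyl to methyl, so the result ties the lower number of compound 1 to the longer branch, yet nothing available explains why the branch has this effect.

The compounds shown leave open whether a longer chain at this place, such as butyl, would lower the number further or raise it again, and whether a branch of in-between length would give an in-between value. They also leave open how a branch carrying a hydroxyl or an amine would behave here.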